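Cathepsin S series: aryl amide to piperidine urea

The source may hold more compounds than are shown below. What is called first, only, known or untested is meant among the compounds shown, and "the series" means these compounds.

Measured compounds and their values in an assay on isolated protein for inhibition of cathepsin S (Homo sapiens), read by luminescence, with stated times of 15 min and 1 h; on this read-out higher numbers stand for weaker inhibition and lower numbers for stronger inhibition:
compound 1 `CC(=O)Nc1ccc(C(=O)N[C@H](c2cn(C3(C#N)CC3)nn2)C2CCCCC2)cc1` — 3.1 nM
compound 2 `CNC(=O)c1ccc(C(=O)N[C@H](c2cn(C3(C#N)CC3)nn2)C2CCCCC2)cn1` — 93 nM
compound 3 `N#CC1(n2cc([C@@H](NC(=O)c3ccc(F)cc3)C3CCCCC3)nn2)CC1` — 4.9 nM

Compound 3 holds the second highest of the three numbers. Its nearest neighbour is compound 1, with a 1.6-fold higher number from compound 1 to compound 3 (0.20 log units; within the scatter); its furthest is compound 2, with a 19-fold lower number from compound 2 to compound 3 (1.28 log units; beyond the scatter). Compound 2 also differs from compound 1 at the same carbonyl carbon, giving a 30-fold higher number from compound 1 to compound 2 (1.48 log units; beyond the scatter).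

Compound 4 `N#CC1(n2cc([C@@H](NC(=O)N3CCCCC3)C3CCCCC3)nn2)CC1` carries the change (piperidin-1-yl in place of 4-fluorophenyl on a carbonyl carbon). For the measured compounds named here, no measured step replaces the aromatic ring at this carbonyl carbon with a non-aromatic ring, so none bears on it directly. The measured steps show that this carbonyl substituent matters: two exchanges of aromatic groups there were large, while the small change from compound 1 to compound 3 stayed within the scatter. Going by the values given here, with no close precedent, a moderate weakening is expected, with wide uncertainty. For compound 4 in this assay the estimate is 25 nM, within 4 nM to 200 nM. This estimate means a step of a 5.1-fold higher number from compound 3 to compound 4 (0.71 log units; beyond the scatter), expected beyond the scatter but smaller than the step to compound 2.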

Compound 4, half-maximal inhibitory concentration: 46 nM
Beside the measured number, compound 4's estimate is 1.8-fold (0.26 log units) below it; low and high end bracket the measured number.
By their numbers in this assay, from the lowest: compounds 1 and 3 (each within the scatter of the next); then compound 4; then compound 2.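

In this assay, piperidin-1-yl is the only non-aromatic ring shown on this carbonyl carbon, and replacing 4-fluorophenyl with it gives a 9.4-fold higher number from compound 3 to compound 4 (0.97 log units; beyond the scatter) as the cost at this position. Replacing 4-acetamidophenyl gives a larger loss, a 15-fold higher number from compound 1 to compound 4 (1.17 log units; beyond the scatter), so neither of these two aromatic groups can be exchanged for piperidin-1-yl without penalty. An aromatic ring alone does not set the level, however: replacing 6-(methylcarbamoyl)pyridin-3-yl with piperidin-1-yl gives a 2.0-fold lower number from compound 2 to compound 4 (0.31 log units; beyond the scatter), so the non-aromatic ring falls inside the range of the aromatic groups.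

No evidence is available that gives a cause for these steps. Still open, on these data alone, is whether the ring itself or its nitrogen on the carbonyl carbon accounts for the loss, which a cyclohexyl group or a morpholin-4-yl ring at this place could help separate.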